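A few compounds are considered here, and "the series" means these few. Any claim that something is new, unique, unknown or untested is made for them only; others in the source may bear on it.

Of the compounds shown here, two have been measured so far. Compound 1, `O=C(O)Cc1sc(NC(=O)c2ccccc2)nc1-c1ccc(Cl)cc1`, gives 870 nM in an in vitro functional assay on HEK285-7 cells for antagonist activity at prostaglandin D2 receptor 2 (Homo sapiens), read by BRET and beta-arrestin recruitment; a higher number here means a weaker inhibitor, a lower number a stronger inhibitor. Compound 2, `O=C(O)Cc1sc(C(c2ccc(F)cc2)c2ccc(F)cc2)nc1-c1cc(F)cc(F)c1`, gives 340 nM in this assay, and this is the lower of the two numbers; the gap between compound 1 and compound 2 lies beyond the usual scatter of repeated measurements, so compound 2 is the stronger inhibitor of the pair. The next compound, compound 3, `Nc1cc(-c2nc(C(c3ccc(F)cc3)c3ccc(F)cc3)sc2CC(=O)O)cc(F)n1`, has not yet been measured. It differs from compound 2 in one place: 2-amino-6-fluoropyridin-4-yl in place of 3,5-difluorophenyl on an aromatic carbon. Among the compounds with values here, no pair of measured compounds differs in just this way, so the numbers in hand say nothing about how such an exchange acts at that carbon. The expectation is therefore a cautious one: compound 3 is expected to land near compound 2, with the estimated value for compound 3 in this assay at 280 nM, and a range from 70 nM to 1100 nM. The step this estimate implies, a 1.2-fold lower number from compound 2 to compound 3 (0.08 log units; within the scatter), is expected to be small, either direction possible and none beyond the scatter being the likeliest outcome.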

Compound 3, half-maximal inhibitory concentration: 1400 nM
For compound 3 the middle estimate is 5.0-fold (0.70 log units) below the measured one; measured number outside the range, above it.
By their numbers in this assay, from the lowest: compound 2; then compounds 1 and 3 (each within the scatter of the next).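

In this assay, the aromatic carbon next to the ring nitrogen proves sensitive to the group it carries: 2-amino-6-fluoropyridin-4-yl in place of 3,5-difluorophenyl gives a 4.1-fold higher number from compound 2 to compound 3 (0.61 log units; beyond the scatter), so compound 3 is the weaker inhibitor of this pair. Both groups hold 8 heavy atoms and one six-membered aromatic ring, so at this position a match in size by that count does not keep the number in place, at least for this exchange, in which a ring of carbon only gives way to a ring with 1 hetero atom, and a group with no hydrogen-bond donors or acceptors to one with 1 donor and 2 acceptors. Nothing available explains this step.

The exchange alters several things at once, and the compounds shown do not separate the effect of the amine from that of the ring nitrogen or of the lost fluorine. On these data alone, a 2-fluoropyridin-4-yl group, which lacks the amine, and a 3-amino-5-fluorophenyl group, which lacks the ring nitrogen, would each isolate one of these parts, and how either behaves at this carbon remains open.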